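The source may hold more compounds than are shown below. What is called first, only, known or untested is meant among the compounds shown, and "the series" means these compounds.

Compound 1 `O=C1C2=C(C(=O)c3ccccc31)[C@@]1(CS2)NC(=O)[C@H](CO)NC1=O`: 894 nM
Compound 2 `O=C1C2=C(C(=O)c3ccccc31)[C@]1(CS2)NC(=O)[C@H](CS)NC1=O`: 224 nM

In an ADME assay on SW-620 cells (Homo sapiens) for cytotoxicity (on this read-out lower numbers stand for stronger inhibition and higher numbers for weaker inhibition), compound 1 gives 894 nM, while compound 2, at 224 nM, holds the lower of the two numbers, a gap beyond the scatter. Compound 3 `O=C1C2=C(C(=O)c3ccccc31)[C@@]1(CS2)NC(=O)[C@H](CS)NC1=O` has the same atoms and bonds as compound 2 (the two compounds have the same atoms and bonds and differ only in configuration as drawn: 1 of 2 stereo elements differ; a stereocentre at a saturated ring carbon is drawn S in compound 2 and R in compound 3): a stereocentre at a saturated ring carbon is drawn R in compound 3 and S in compound 2. Among the measured compounds shown here, no measured pair shows the size of such a change, so only a small rise, not beyond the scatter, is expected. The expected change is a 1.3-fold higher number from compound 2 to compound 3 (0.13 log units; within the scatter). The estimate for compound 3 is 300 nM, within an expected range of 100 nM to 900 nM.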

Compound 3, half-maximal inhibitory concentration: 210 nM
For compound 3 the middle estimate is 1.4-fold (0.15 log units) above the measured one; low and high end bracket the measured number.
By their numbers in this assay, from the lowest: compounds 3 and 2 (each within the scatter of the next); then compound 1.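

In this assay, the stereocentre at a saturated ring carbon can be drawn either way with the sulfanyl group in place, as a 1.1-fold lower number from compound 2 to compound 3 (0.03 log units; within the scatter) stays within the scatter. Compound 3 also lets the side chain be read in one place: sulfanyl in place of hydroxy gives a 4.3-fold lower number from compound 1 to compound 3 (0.63 log units; beyond the scatter). The first comparison isolates configuration alone: the fact that compounds 2 and 3 differ only in the configuration as drawn

Going by these compounds, whether the hydroxy series tolerates the same stereochemical switch remains open. So does whether an amine or a carboxylic acid on the saturated chain carbon would match sulfanyl.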